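Halogen swap on the aryl ring: chloro to fluoro

The compounds below may be only part of what the source reports. "The series", "measured", "known", "first", "only" and "open" are said of these compounds alone.

Measured so far:
compound 1 `CC(=O)OC[C@H]1O[C@H](OC[C@@H](Cn2cc(CN(c3nc(-c4ccc([N+](=O)[O-])cc4)no3)C3CCCCC3)nn2)OC(C)=O)C=C[C@@H]1OC(C)=O`: 64.1 ug/mL
compound 2 `CC(=O)OC[C@H]1O[C@H](OC[C@@H](Cn2cc(CN(c3nc(-c4ccc(Cl)cc4)no3)C3CCCCC3)nn2)OC(C)=O)C=C[C@@H]1OC(C)=O`: 35.5 ug/mL

Of the compounds shown here, two sharing one core have been tested in an ADME assay on RAW264.7 cells (Mus musculus) for cytotoxicity, read by MTT assay, with a stated time of 48 h; a higher number here means that more compound is tolerated, a lower number that less compound is tolerated. Compound 1 `CC(=O)OC[C@H]1O[C@H](OC[C@@H](Cn2cc(CN(c3nc(-c4ccc([N+](=O)[O-])cc4)no3)C3CCCCC3)nn2)OC(C)=O)C=C[C@@H]1OC(C)=O` gives 64.1 ug/mL, and compound 2 `CC(=O)OC[C@H]1O[C@H](OC[C@@H](Cn2cc(CN(c3nc(-c4ccc(Cl)cc4)no3)C3CCCCC3)nn2)OC(C)=O)C=C[C@@H]1OC(C)=O` gives 35.5 ug/mL. Among the measured compounds shown here, compound 2 has the lowest of the two numbers, but the only step between them, a 1.8-fold lower number from compound 1 to compound 2 (0.26 log units; within the scatter), is within the scatter, so the two cannot be told apart on these data.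

Compound 3 `CC(=O)OC[C@H]1O[C@H](OC[C@@H](Cn2cc(CN(c3nc(-c4ccc(F)cc4)no3)C3CCCCC3)nn2)OC(C)=O)C=C[C@@H]1OC(C)=O` has not yet been measured. It differs from compound 2 in one place: fluoro in place of chloro on an aromatic carbon. For the measured compounds named here, the one measured step that bears on this is the halogen-for-nitro exchange at the same aromatic carbon, a 1.8-fold lower number from compound 1 to compound 2 (0.26 log units; within the scatter), which was small. A chloro-to-fluoro exchange is a smaller change than nitro-to-chloro, and nothing in the data points to a shift beyond the scatter. For compound 3 the expected step is therefore a 1.1-fold higher number from compound 2 to compound 3 (0.05 log units; within the scatter), essentially no movement. The estimate for compound 3 in this assay is 40 ug/mL, with a range from 20 ug/mL to 80 ug/mL.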

Compound 3, half-maximal cytotoxic concentration: 31.5 ug/mL
Estimate against measurement, compound 3: 1.3-fold (0.10 log units) above; measured number inside the range.
By their numbers in this assay, from the lowest: compounds 3, 2 and 1 (each within the scatter of the next, the first and the last beyond it).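

In this assay the swap between the two halogens on this aromatic carbon, para to a large group, does not separate the compounds: a 1.1-fold lower number from compound 2 to compound 3 (0.05 log units; within the scatter) and so compound 2 and compound 3 cannot be told apart. Among the compounds shown here, the change from nitro to fluoro gives the first step at this position that clears the scatter, with a 2.0-fold lower number from compound 1 to compound 3 (0.31 log units; beyond the scatter) and a modest size, whereas the change from nitro to chloro, with a 1.8-fold lower number from compound 1 to compound 2 (0.26 log units; within the scatter) and no more, stays inside it. The gap between the nitro compound and the two halogen compounds is therefore small, and only the fluoro compound can be told apart from compound 1, so this is a slight difference rather than a clear split between nitro and halogen; no measurement shown here explains these numbers.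

From the compounds shown here alone, it remains open how a hydrogen, a methoxy group, an amine or a carboxylic acid at this position would read in this assay and whether any of them would move the number further than nitro and the halogens do. Every change so far falls on this one aromatic carbon, so nothing shown speaks to the rest of the shared core.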